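The source may report more compounds than this note shows. Statements on the series, on what has been measured and on what is new or still open speak of the compounds shown alone.

Compound 1 `CCn1c(N)c(-c2nc3ccccc3[nH]2)c2nc(C#N)c(C#N)nc21` is the parent without a basic side group.
Compound 2 `N#Cc1nc2c(-c3nc4ccccc4[nH]3)c(N)n(CCN3CCCC3)c2nc1C#N` carries a pyrrolidin-1-yl on the chain.
Compound 3 `CN1CCN(CCn2c(N)c(-c3nc4ccccc4[nH]3)c3nc(C#N)c(C#N)nc32)CC1` carries a 4-methylpiperazin-1-yl on the chain.

In a functional assay on HL-60 cells (Homo sapiens) for antiproliferative activity, read by MTT assay, with a stated time of 48 h (a lower number here means a stronger inhibitor, a higher number a weaker inhibitor), compound 1 gives > 50000 nM, which is a limit of the assay rather than a number. Compound 1 thus sits at the limit of > 50000 nM in this assay, at which 1 of the 3 values shown sits. In this assay compound 2 gives 4760 nM and compound 3 gives 4300 nM. Compound 2 holds the highest of the two numbers, with compound 3 nearest: a 1.1-fold lower number from compound 2 to compound 3 (0.04 log units; within the scatter). Against the parent the steps were large: an at least 10-fold lower number from compound 1 to compound 2 (1.02 log units; beyond the scatter) and an at least 11-fold lower number from compound 1 to compound 3 (1.06 log units; beyond the scatter).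

Compound 4 `CN1CCN(CCCn2c(N)c(-c3nc4ccccc4[nH]3)c3nc(C#N)c(C#N)nc32)CC1` is not yet measured. It differs from compound 2 by (4-methylpiperazin-1-yl)methyl in place of pyrrolidin-1-yl on a saturated chain carbon, two bonds along the chain from an aromatic nitrogen. The step from compound 2 to compound 3, which also swaps pyrrolidin-1-yl for 4-methylpiperazin-1-yl, was within the scatter, so the added chain length is the only untested part. Compound 4 is therefore expected near compound 2, with a 1.1-fold lower number from compound 2 to compound 4 (0.05 log units; within the scatter) not beyond the scatter, and an estimated 4200 nM in this assay, ranging from 1500 nM to 12000 nM.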

Compound 4, half-maximal inhibitory concentration: 750 nM
Beside the measured number, compound 4's estimate is 5.6-fold (0.75 log units) above it; the whole stated range lies above it.
By their numbers in this assay, from the lowest: compound 4; then compounds 3 and 2 (each within the scatter of the next). At a limit, above all of these: compound 1.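

With the 4-methylpiperazin-1-yl group held fixed, lengthening 2-(4-methylpiperazin-1-yl)ethyl to 3-(4-methylpiperazin-1-yl)propyl gave a 5.7-fold lower number from compound 3 to compound 4 (0.76 log units; beyond the scatter) in this assay, so chain length at this position matters, whereas the earlier exchange of terminal rings on the shorter chain stayed within the scatter. The full change from 2-(pyrrolidin-1-yl)ethyl to 3-(4-methylpiperazin-1-yl)propyl gave a 6.3-fold lower number from compound 2 to compound 4 (0.80 log units; beyond the scatter), and the distance from the parent widened to an at least 66-fold lower number from compound 1 to compound 4 (1.82 log units; beyond the scatter). That last step rests on compound 1, whose value is a limit and not a number: the limit of > 50000 nM in this assay, at which 1 of the 4 values shown sits.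

The compounds shown leave open whether a 3-(pyrrolidin-1-yl)propyl chain would behave like compound 4, which would show whether the longer chain helps with another terminal ring. They also leave open whether a butyl chain carrying the same 4-methylpiperazin-1-yl group would go further, or whether a morpholine would serve in its place.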